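The compounds below may be only part of what the source reports. "The series", "measured", "known", "first", "only" and "open" are said of these compounds alone.

In an ADME assay on SH-SY5Y cells (Homo sapiens) for cytotoxicity, read by MTT assay, with a stated time of 24 h, tested at 12.5 uM (on this read-out higher numbers stand for a weaker effect at the one concentration tested and lower numbers for a stronger effect), compound 2 `COc1cc2c(cc1O)CCC(C)(CC(N)=O)O2` gives 100%, the highest of the two numbers shown; compound 1 `COc1cc2c(cc1O)CCC(C)(CC(=O)N[C@H](C(=O)O)C(C)C)O2` gives 82.6%. Compound 3 `COc1cc2c(cc1O)CCC(C)(CC(=O)N[C@@H](CCC(N)=O)C(=O)O)O2` differs from compound 2 in one place: 3-carbamoyl-1-carboxypropyl in place of hydrogen on an amide-type nitrogen. Among the measured compounds shown here, one measured step bears on this: the change a number 17.4 percentage points higher from compound 1 to compound 2 (beyond the scatter), where a carboxy-bearing group left the same amide-type nitrogen and the number rose. Putting a carboxy-bearing group back on that nitrogen is therefore expected to move the number downward by a modest amount, a number 15 percentage points lower from compound 2 to compound 3 (beyond the scatter). Compound 3 is estimated at 85%, with a range from 70% to 100%.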

Compound 3, a percentage reported as activity, at one concentration (the size of the read-out at that concentration, not a potency): 84.8%
Beside the measured number, compound 3's estimate is 0.2 percentage points above it; measured number inside the range.
By their numbers in this assay, from the lowest: compounds 1 and 3 (each within the scatter of the next); then compound 2.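

A second carboxy-bearing group on the amide-type nitrogen also brings the number down, a number 15.2 percentage points lower from compound 2 to compound 3 (beyond the scatter), so this drop is not tied to the side chain of compound 1 alone. Changing that side chain from isopropyl to 2-carbamoylethyl leaves no readable difference, a number 2.2 percentage points higher from compound 1 to compound 3 (within the scatter). Nothing measured here gives a reason for the drop.

From the compounds shown here alone, compound 1 and compound 3 each carry the carboxylic acid and a side chain together, so which part matters stays open. A methyl ester in place of the acid, or a plain acetic acid chain without a side chain, would separate them.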